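Primary amine chain extension on a fluoroindole myeloperoxidase inhibitor

The compounds below may be only part of what the source reports. "The series", "measured", "known", "first", "only" and "open" are said of these compounds alone.

Measured compounds:
compound 1, `CCN(CC)Cc1c[nH]c2ccc(F)cc12`: 200 nM
compound 2, `NCCCc1c[nH]c2ccc(F)cc12`: 50 nM
compound 3, `CCCNCCCc1c[nH]c2ccc(F)cc12`: 170 nM

All three were tested in an assay on urine for inhibition of Myeloperoxidase (Homo sapiens); on this read-out higher numbers stand for weaker inhibition and lower numbers for stronger inhibition. Compound 3 stands second highest of the three numbers; compound 1 lies within the scatter of it, while compound 2 sits clearly lower, as the step of a 3.4-fold higher number from compound 2 to compound 3 (0.53 log units; beyond the scatter) shows. Compound 4, `NCCCCc1c[nH]c2ccc(F)cc12`, has not yet been measured in this assay. Relative to compound 3 the change is aminomethyl in place of propylamino on a saturated chain carbon, three bonds along the chain from an aromatic carbon. Among the compounds with values here, two measured steps bear on it. The step of a 3.4-fold higher number from compound 2 to compound 3 (0.53 log units; beyond the scatter) shows that adding propyl to the amine nitrogen of compound 2 raised the number; compound 4 undoes that propyl while lengthening the chain by one carbon. The step of a 4.0-fold lower number from compound 1 to compound 2 (0.60 log units; beyond the scatter) likewise shows a lower number when a primary amine replaces a dialkylated one. Within the data shown here, no measured pair speaks to the extra chain carbon alone. Because of a 3.4-fold higher number from compound 2 to compound 3 (0.53 log units; beyond the scatter) a modest drop is expected when the propyl is removed again; for compound 4 that points to a number below compound 3, tempered by the unknown effect of chain length. Compound 4 is therefore estimated at 70 nM in this assay, within 30 nM to 170 nM, which means an expected step of a 2.4-fold lower number from compound 3 to compound 4 (0.39 log units; beyond the scatter).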

Compound 4, half-maximal inhibitory concentration: 15 nM
For compound 4 the middle estimate is 4.7-fold (0.67 log units) above the measured one, and the stated range ends above it.
By their numbers in this assay, from the lowest: compound 4; then compound 2; then compounds 3 and 1 (each within the scatter of the next).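

In this assay, within the data shown here, the chain itself now has a measured effect: with the primary amine kept, aminomethyl in place of amino gives a 3.3-fold lower number from compound 2 to compound 4 (0.52 log units; beyond the scatter) and makes compound 4 the strongest inhibitor of the four, something no earlier pair could isolate. Set against the substituted amines, the same free amine on the longer chain gives an 11-fold lower number from compound 3 to compound 4 (1.05 log units; beyond the scatter) and a 13-fold lower number from compound 1 to compound 4 (1.12 log units; beyond the scatter), two large steps where all the earlier ones were modest, so this saturated chain position still had room for a lower number after compound 2. The data shown offer no independent measurement that explains this gain.

Going by these compounds, what remains open is whether a still longer chain ending in a primary amine would lower the number further or reverse the trend seen from compound 2 to compound 4, since only these two primary amines on a chain of this kind can be compared. It is also unknown whether a propyl group on the nitrogen of compound 4 would raise the number as it did on compound 2, or whether a carboxylic acid could stand in place of the amine.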